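The source may report more compounds than this note shows. Statements on the series, on what has been measured and on what is new or still open speak of the compounds shown alone.

Measured so far:
Compound 1 `O=C(c1cccc(/C=c2\[nH]c(=O)/c(=C/c3ccccn3)[nH]c2=O)c1)N1CCC1`: > 500 nM
Compound 2 `O=C(c1cccc(/C=c2\[nH]c(=O)/c(=C/c3ccccn3)[nH]c2=O)c1)N1CCCCC1`: > 500 nM
Compound 3 `CC(C)(C)c1[nH]cnc1/C=c1\[nH]c(=O)/c(=C/c2cccc(C(=O)c3ccsc3)c2)[nH]c1=O`: 1.56 nM

All three values come from a functional assay on BXPC-3 cells (Homo sapiens) for antiproliferative activity, read by sulforhodamine B assay, with a stated time of 72 h; on this read-out higher numbers stand for weaker inhibition and lower numbers for stronger inhibition. Compound 1 gives > 500 nM, which is a limit and not a number. Compound 2 gives > 500 nM, which is also a limit. Among the measured compounds shown here, compound 3, at 1.56 nM, therefore has the only exact number in the set. The rest of the data sit together: the limit of > 500 nM in this assay, at which 2 of the 3 values shown sit.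

Compound 4 `CC(C)(C)c1[nH]cnc1/C=c1\[nH]c(=O)/c(=C/c2cccc(C(=O)c3cc[nH]c3)c2)[nH]c1=O` differs from compound 3 at one place, with 1H-pyrrol-3-yl in place of thiophen-3-yl on a carbonyl carbon. For the measured compounds named here, the one measured step, a step that the two limits leave unreadable from compound 1 to compound 2, also changes a group on a carbonyl carbon, but it offers no size to carry over. The expectation therefore rests on the value of compound 3, 1.56 nM, and on the counted change alone, and it is a loose one. A modest weakening is expected: a 3.2-fold higher number from compound 3 to compound 4 (0.51 log units; beyond the scatter). For compound 4 the estimated value in this assay is 5 nM, with an expected range of 1.2 nM to 30 nM.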

Compound 4, half-maximal inhibitory concentration: > 100 nM
Compound 4: no number, only a limit (the forecaster's own chance of this, stated with the estimate: 3%); middle value at least 20-fold (1.30 log units) from the limit.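

In this assay, putting 1H-pyrrol-3-yl in place of thiophen-3-yl on the carbonyl carbon gives an at least 64-fold higher number from compound 3 to compound 4 (1.80 log units; beyond the scatter), so this position proves highly sensitive, even though both groups are five-membered aromatic rings with one hetero atom. The earlier pair gave no such size, since the step between compound 1 and compound 2 cannot be read. Nothing measured in this set explains why the ring nitrogen with its hydrogen is tolerated so much worse than the ring sulfur.

As far as these compounds go, it stays open whether the loss follows the hydrogen on the ring nitrogen, which a 1-methyl-1H-pyrrol-3-yl group on the same carbonyl would test. From the compounds shown here alone, it also stays open whether a furan-3-yl group, with a ring oxygen, would stay close to compound 3 at 1.56 nM.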